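Piperidin-1-yl in place of chloro: solubility notes

A few compounds are considered here, and "the series" means these few. Any claim that something is new, unique, unknown or untested is made for them only; others in the source may bear on it.

Measured so far:
- Compound 1 `Clc1ccc2c(NCCCNc3ccnc(N4CCCCC4)n3)ccnc2c1` gives 320 nM in a physicochemical assay for solubility, read by HPLC, in phosphate buffer, with a stated time of 24 h, at pH 7.4; on this read-out lower numbers stand for lower solubility and higher numbers for higher solubility.
- Compound 2 `Clc1ccc2c(NCCCNc3nccc(Cl)n3)ccnc2c1` gives 400 nM in this assay.
- Compound 3 `Clc1ccc2c(NCCCNc3ccnc(Cl)n3)ccnc2c1` gives 600 nM in this assay.

Compound 4 `Clc1ccc2c(NCCCNc3nccc(N4CCCCC4)n3)ccnc2c1` is not yet measured. It differs from compound 2 by piperidin-1-yl in place of chloro on an aromatic carbon. The same kind of change has already been made once, from compound 3 to compound 1, where it reads piperidin-1-yl in place of chloro on an aromatic carbon and gave a 1.9-fold lower number from compound 3 to compound 1 (0.27 log units; within the scatter). The surroundings are not identical: in that earlier pair the site is between two ring nitrogen atoms, whereas in compound 4 it is next to the ring nitrogen and opposite the ring nitrogen, so the two changes are of the same kind rather than the same.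

The two cores differ by 4-chloropyrimidin-2-yl in place of 2-chloropyrimidin-4-yl on an amine nitrogen, and that difference gave a 1.5-fold higher number from compound 2 to compound 3 (0.18 log units; within the scatter). All three measured values lie within the scatter of one another.

From compound 2 to compound 4 the expected step is a 1.6-fold lower number from compound 2 to compound 4 (0.20 log units; within the scatter), resting on the earlier step of a 1.9-fold lower number from compound 3 to compound 1 (0.27 log units; within the scatter) from compound 3. Compound 4 is therefore estimated at 250 nM, with a range of 120 nM to 550 nM.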

Compound 4, solubility: 250 nM
Compound 4: the middle estimate sits on the measured number at the digits printed; measured number inside the range.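

Piperidin-1-yl in place of chloro on an aromatic carbon has now been read on two cores in this assay and gives a 1.6-fold lower number from compound 2 to compound 4 (0.20 log units; within the scatter) on one and a 1.9-fold lower number from compound 3 to compound 1 (0.27 log units; within the scatter) on the other. Within the data shown here, both steps lie within the scatter, so the pair shows only that this change, carried from one core to the other, has stayed within the scatter on both; it does not show that the change truly lowers the number, nor that the same would hold on any further core. The measurements shown offer nothing that bears on the reason for either step.

Going by these compounds, whether a dimethylamino group, a morpholin-4-yl group or a carboxylic acid on the same aromatic carbon would give a step beyond the scatter remains open. So does the reading of either core with a longer chain linking the two amine nitrogens.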